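The source may report more compounds than this note shows. Statements on the series, on what has been measured and on what is new or still open speak of the compounds shown alone.

Compound 1 `O=C(NC(=S)N1CCc2c(OCCCCCOc3ccc(Cl)cc3)cccc21)c1ccc([N+](=O)[O-])cc1`: 13600 nM
Compound 2 `O=S(=O)(NC(=S)N1CCc2c(OCCCCCOc3ccc(Cl)cc3)cccc21)c1ccccc1`: > 50000 nM

In an ADME assay on Huh-7 cells (Homo sapiens) for cytotoxicity (a higher number here means that more compound is tolerated, a lower number that less compound is tolerated), compound 1 gives 13600 nM. For compound 2 the result is > 50000 nM, which is a limit of this assay and not a number, so compound 2 stands at the top end of the two values shown (the limit of > 50000 nM in this assay, at which 1 of the 2 values shown sits). The step of an at least 3.6-fold higher number from compound 1 to compound 2 (0.56 log units; beyond the scatter) is the only measured one, and it runs toward a more tolerated compound. Compound 3 `S=C(NC(=S)N1CCc2c(OCCCCCOc3ccc(Cl)cc3)cccc21)Oc1ccccc1` differs from compound 2 by a group of 9 heavy atoms (7 carbon, 1 oxygen, 1 sulfur; one six-membered aromatic ring of carbon only) in place of a group of 9 heavy atoms (6 carbon, 2 oxygen, 1 sulfur; one six-membered aromatic ring of carbon only), on an amide-type nitrogen. That change again replaces the whole group on the amide-type nitrogen, as the measured step did, but no measured pair shows this particular exchange, so the direction is open, and the measured step gives no reason to expect a large fall. Compound 3 is therefore expected to sit near the limit, a number no higher from compound 2 to compound 3 (the limit leaves the size open), with an estimated value of 50000 nM and a range from 15000 nM to 150000 nM.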

Compound 3, half-maximal cytotoxic concentration: > 50000 nM
Compound 3 gave a limit, no number (the forecaster's own chance of this, stated with the estimate: 60%); the middle value lies on the limit itself.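

In this assay compound 3 gives > 50000 nM, which is a limit of the assay and not a number. Exchanging the (4-nitrophenyl)carbonyl group on the amide-type nitrogen for the sulfur-bearing group that enters here gives an at least 3.6-fold higher number from compound 1 to compound 3 (0.56 log units; beyond the scatter), so phenylsulfonyl is no longer the only group shown to exceed compound 1 in this way. The step between compound 2 and compound 3 cannot be read, and the result adds a second compound at the same limit: the limit of > 50000 nM in this assay, at which 2 of the 3 values shown sit.

The compounds shown do not tell whether the lower number of compound 1 belongs to its carbonyl or to its nitro group, or how far compound 2 and compound 3 lie beyond the limit. They also leave open how an acetyl group or an amine on that nitrogen would fare in this assay.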